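Swapping a fluorinated branched chain for a methylcyclohexyl ring

The source may report more compounds than this note shows. Statements on the series, on what has been measured and on what is new or still open speak of the compounds shown alone.

Compound 1, `Cc1nc(NC(=O)C(C)(C)CC(F)(F)F)sc1-c1ccc(N)nc1`: 41 10^-6 cm/s
Compound 2, `Cc1nc(NC(=O)CN2C(=O)OC[C@H]2C(C)C)sc1-c1ccc(N)cc1`: 19 10^-6 cm/s

Both numbers come from an ADME assay on Caco-2 cells (Homo sapiens) for permeability, in the apical to basolateral direction; a higher number here means that the compound crosses the layer faster, a lower number that the compound crosses the layer more slowly. Compound 1 has the higher of the two; compound 2 sits a step below it that lies beyond the usual scatter. Compound 3, `Cc1nc(NC(=O)C2(C)CCCCC2)sc1-c1ccc(N)nc1`, has not been measured. It differs from compound 1 in one place: 1-methylcyclohexyl in place of 3,3,3-trifluoro-1,1-dimethylpropyl on a carbonyl carbon. Among the compounds with values here, no measured pair shows a change of this kind, so the expectation rests on compound 1 alone. In this assay a step from compound 1 to compound 3 is expected to stay within the scatter, in neither direction. Compound 3 is expected to give 35 10^-6 cm/s, within 18 10^-6 cm/s to 70 10^-6 cm/s. That means a step of a 1.2-fold lower number from compound 1 to compound 3 (0.07 log units; within the scatter) is expected.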

Compound 3, apparent permeability in the Caco-2 assay: 20 10^-6 cm/s
Compound 3: middle estimate off by 1.8-fold (0.24 log units), on the high side; the measured number falls inside the stated range.
By their numbers in the Caco-2 assay, from the lowest: compounds 2 and 3 (each within the scatter of the next); then compound 1.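

Compound 3 carries 1-methylcyclohexyl in place of 3,3,3-trifluoro-1,1-dimethylpropyl on a carbonyl carbon. In the Caco-2 assay, compound 1 gives 41 10^-6 cm/s and compound 3 gives 20 10^-6 cm/s. In the Caco-2 assay, this change is a 2.1-fold lower number from compound 1 to compound 3 (0.31 log units; beyond the scatter). In a physicochemical assay for solubility, at pH 6.8 (on this read-out lower numbers stand for lower solubility and higher numbers for higher solubility), compound 1 gives 13 ug/mL and compound 3 gives 8.7 ug/mL. In the physicochemical assay, the same change gives a 1.5-fold lower number from compound 1 to compound 3 (0.17 log units; within the scatter) and so does not clearly separate the two compounds on that read-out. No measurement available here accounts for the permeability step.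

The compounds shown do not separate the loss of fluorine from the presence of the ring. An open chain of carbon only, such as a tert-butyl group, at the same place would address that question.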